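Shortening the ether chain: compound 2 to compound 4

The compounds below may be only part of what the source reports. "The series", "measured", "known", "first", "only" and "open" are said of these compounds alone.

Compound 1 `NCCOc1ccc([C@H]2CC[C@]3(CC2)OOC2(O3)C3CC4CC(C3)CC2C4)cc1` gives 287 nM
Compound 2 `c1cc([C@H]2CC[C@]3(CC2)OOC2(O3)C3CC4CC(C3)CC2C4)ccc1OCCOC1CCNCC1` gives 633 nM
Compound 3 `CC(C)(O)CN1CCC(Oc2ccc([C@H]3CC[C@]4(CC3)OOC3(O4)C4CC5CC(C4)CC3C5)cc2)CC1` gives 1810 nM

In an ADME assay on the whole organism (strain FVB) for pharmacokinetics, with Mus musculus as the target, read by LC-MS, at a dose of 30 mg/kg by the oral route (on this read-out lower numbers stand for lower exposure and higher numbers for higher exposure at the dose given), compound 2 stands second highest of the three at 633 nM and is clearly separated from both neighbours. Compound 4 `c1cc([C@H]2CC[C@]3(CC2)OOC2(O3)C3CC4CC(C3)CC2C4)ccc1OC1CCNCC1` differs from compound 2 by piperidin-4-yl in place of 2-((piperidin-4-yl)oxy)ethyl on an oxygen on an aromatic ring, with piperidin-4-yl in place of 2-((piperidin-4-yl)oxy)ethyl on an oxygen on an aromatic ring. The closest measured change is a 2.9-fold higher number from compound 2 to compound 3 (0.46 log units; beyond the scatter), where 1-(2-hydroxy-2-methylpropyl)piperidin-4-yl enters at that same place. The other relevant change, a 2.2-fold higher number from compound 1 to compound 2 (0.34 log units; beyond the scatter), is also modest. For the measured compounds named here, no measured compound carries the unsubstituted piperidin-4-yl on that oxygen, so a small upward move in this assay is expected, not clearly beyond the scatter. The expected change is a 1.6-fold higher number from compound 2 to compound 4 (0.20 log units; within the scatter). Compound 4 is estimated at 1000 nM, with an expected range from 350 nM to 2800 nM.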

Compound 4, maximal plasma concentration: 810 nM
Beside the measured number, compound 4's estimate is 1.2-fold (0.09 log units) above it, within the range that was stated.
By their numbers in this assay, from the lowest: compound 1; then compounds 2 and 4 (each within the scatter of the next); then compound 3.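

In this assay piperidin-4-yl in place of 2-((piperidin-4-yl)oxy)ethyl on the oxygen on the aromatic ring gives no readable difference (a 1.3-fold higher number from compound 2 to compound 4 (0.11 log units; within the scatter)). Steps beyond the scatter do appear for hydrogen in place of 2-hydroxy-2-methylpropyl on the amine nitrogen in the ring (a 2.2-fold lower number from compound 3 to compound 4 (0.35 log units; beyond the scatter)) and for piperidin-4-yl in place of 2-aminoethyl on that oxygen (a 2.8-fold higher number from compound 1 to compound 4 (0.45 log units; beyond the scatter)). No evidence on hand accounts for these steps.

Open, on these data alone, is how other groups on that amine nitrogen, such as methyl or acetyl, would read here. As far as these compounds go, a longer chain carrying a hydroxyl group on that nitrogen also remains open.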